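The source may report more compounds than this note shows. Statements on the series, on what has been measured and on what is new or still open speak of the compounds shown alone.

Compound 1, with structure `COc1ccnc(CNc2ccc3c(c2)nc(C)n3C[C@@H](O)[C@H]2O[C@H](O)[C@@H](O)[C@H]2O)c1C`, was tested in a functional assay on the whole organism (strain Sprague-Dawley) for inhibition, with Rattus norvegicus as the target, read by paw edema, with a stated time of 180 min, at a dose of 20 mg/kg by the oral route (on this read-out higher numbers stand for a stronger effect at the one dose given and lower numbers for a weaker effect), and in that assay compound 1 gives 53%. Within the data shown here, the only other measured compound, compound 2, with structure `COc1ccnc(CNc2ccc3[nH]c(C)nc3c2)c1OC`, gives 57% in this assay. Compound 1 thus carries the lower of the two numbers, but the gap to compound 2 lies within the scatter of repeated measurements, so the two values cannot be ranked against each other. Compound 3, with structure `Cc1nc2cc(NCc3ccccn3)ccc2n1C[C@@H](O)[C@H]1O[C@H](O)[C@@H](O)[C@H]1O`, has not yet been measured in this assay. It differs from compound 1 in one place: pyridin-2-yl in place of 4-methoxy-3-methylpyridin-2-yl on a saturated chain carbon bound to a nitrogen on an aromatic ring. Among the measured compounds shown here, no step between two measured compounds is available to calibrate this change, and the two values in hand say nothing about it. The expectation for compound 3 is therefore a step of no size beyond the scatter, with a slight lean downward if anything. The estimated step from compound 1 to compound 3 is a number 8 percentage points lower from compound 1 to compound 3 (within the scatter). In this assay compound 3 is expected to give 45%, within a range from 25% to 65%.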

Compound 3, a percentage reported as inhibition, in the whole organism at one dose (the size of the read-out at that dose, not a potency): 47%
Estimate against measurement, compound 3: 2 percentage points below; the range from low to high includes it.
By their numbers in this assay, from the lowest: compounds 3, 1 and 2 (each within the scatter of the next).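

In this assay, among these compounds, putting pyridin-2-yl in place of 4-methoxy-3-methylpyridin-2-yl on a saturated chain carbon bound to a nitrogen on an aromatic ring gives a number 6 percentage points lower from compound 1 to compound 3 (within the scatter), and this is the first reading of any change at this position. In this one pair, the methoxy and methyl groups can go together without the read-out moving beyond the scatter, so at this dose and time the substituted ring and the plain pyridin-2-yl cannot be told apart. Nothing at hand explains why the read-out holds across this change.

On these data alone, it remains open whether the methoxy or the methyl alone would give a step of similar size, and whether a phenyl ring in place of the pyridine, or a dimethylamino group or a carboxylic acid on the ring, would move the number beyond the scatter. Since this read-out gives the size of an effect at one oral dose and not a potency, the pair may still differ at other doses or times, and compound 2 differs from both in more than one place, so it adds nothing to this comparison.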